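Swapping the Basic Amine on the Propoxy Side Chain

A few compounds are considered here, and "the series" means these few. Any claim that something is new, unique, unknown or untested is made for them only; others in the source may bear on it.

Measured so far in a functional assay on HCT-116 cells (Homo sapiens) for cytotoxicity, read by WST assay, with a stated time of 72 h; a lower number here means a stronger inhibitor, a higher number a weaker inhibitor:
Compound 1, `COc1cc2c(Nc3nc4ccc(C(=O)Nc5c(C)cccc5Cl)cc4s3)ncnc2cc1OCCCN1CCCCC1C`: compound 1 gives 7200 nM
Compound 2, `COc1cc2c(Nc3nc4ccc(C(=O)Nc5c(C)cccc5C)cc4s3)ncnc2cc1OCCCN1CCCC1`: compound 2 reaches only the assay limit of > 100000 nM
Compound 3, `CCN(CC)CCCOc1cc2ncnc(Nc3nc4ccc(C(=O)Nc5c(C)cccc5Cl)cc4s3)c2cc1OC`: compound 3 gives 13200 nM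

Compound 3 carries the highest of the two numbers, but its nearest neighbour is compound 1 and the step of a 1.8-fold higher number from compound 1 to compound 3 (0.26 log units; within the scatter) stays within the scatter, so the two cannot be told apart. Compound 2 sits at a limit of > 100000 nM in this assay, at which 1 of the 3 values shown sits, and gives no number to compare.

Compound 4, `COc1cc2c(Nc3nc4ccc(C(=O)Nc5c(C)cccc5Cl)cc4s3)ncnc2cc1OCCCN1CCCC1`, is the next variation: pyrrolidin-1-yl in place of diethylamino on a saturated chain carbon, three bonds along the chain from an oxygen on an aromatic ring. Within the data shown here, the one measured step that touches this position, a 1.8-fold higher number from compound 1 to compound 3 (0.26 log units; within the scatter), changed the amine on the same chain and moved the number by no more than the scatter. Compound 2 also carries the pyrrolidin-1-yl chain, but it differs from compound 4 elsewhere as well, so it offers no clean comparison. On that basis compound 4 is expected to land near compound 3, with a step of a 1.3-fold lower number from compound 3 to compound 4 (0.12 log units; within the scatter) that means no change beyond the scatter. The estimate for compound 4 in this assay is 10000 nM, between 4000 nM and 30000 nM.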

Compound 4, half-maximal inhibitory concentration: 63800 nM
Compound 4: middle estimate off by 6.4-fold (0.80 log units), on the low side, outside the stated range (above it).
By their numbers in this assay, from the lowest: compounds 1 and 3 (each within the scatter of the next); then compound 4. At a limit, above all of these: compound 2.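

In this assay, the amine on this chain makes a modest difference: pyrrolidin-1-yl in place of diethylamino gives a 4.8-fold higher number from compound 3 to compound 4 (0.68 log units; beyond the scatter), even though diethylamino and pyrrolidin-1-yl have the same heavy-atom count and differ in that pyrrolidin-1-yl closes a ring. Having a ring is not enough to explain the number: an 8.9-fold higher number from compound 1 to compound 4 (0.95 log units; beyond the scatter) is also a modest step beyond the scatter, while compound 1, which carries the ring of 2-methylpiperidin-1-yl, and compound 3, which has no ring in its amine, lie within the scatter of each other. Chloro in place of methyl gives an at least 1.5-fold lower number from compound 2 to compound 4 (0.19 log units; that floor lies within the scatter). This step cannot be read as a size, because compound 2 gives only a limit: the limit of > 100000 nM in this assay, at which 1 of the 4 values shown sits.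

The compounds shown leave open whether a plain piperidin-1-yl or a morpholin-4-yl group on the same chain would land nearer compound 1 or compound 4. They also do not show why pyrrolidin-1-yl gives the higher number, or whether a shorter chain would alter it.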